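The source may report more compounds than this note shows. Statements on the series, on what has been measured and on what is new or still open speak of the compounds shown alone.

Measured so far:
compound 1, `NC[C@@H]1CCCc2cc(S(=O)(=O)c3cccc(O)c3)ccc21` — 0.251 nM
compound 2, `NC[C@@H]1CCCc2cc(S(=O)(=O)c3cc(F)cc4[nH]cnc34)ccc21` — 5.01 nM
compound 3, `CN(CC(N)=O)C[C@@H]1CCCc2cc(S(=O)(=O)c3cccc(F)c3)ccc21` — 1.26 nM

Of the compounds shown here, three sharing one core have been tested in an assay on isolated protein for displacement of a labelled ligand from 5-hydroxytryptamine receptor 6 (Homo sapiens); on this read-out higher numbers stand for weaker inhibition and lower numbers for stronger inhibition. Compound 1 gives 0.251 nM, compound 2 gives 5.01 nM, and compound 3 gives 1.26 nM. Among these, compound 3 holds the second highest number: compound 2 sits above it, beyond the scatter, and compound 1 sits below it, also beyond the scatter. Going by the values given here, no pair among the three differs in one place only, so nothing can be said about what any single change does to the numbers; the three values simply stand as they are.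

Compound 4, `O=C(CO)NC[C@@H]1CCCc2cc(S(=O)(=O)c3cccc(F)c3)ccc21`, has not yet been measured in this assay. It differs from compound 3 in one place:

((hydroxymethyl)carbonyl)amino in place of (carbamoylmethyl)(methyl)amino on a saturated chain carbon bound to a saturated ring carbon

Among the compounds with values here, no single-change step between measured compounds is available to anchor what this exchange should do. The expectation is therefore drawn only from the values of compound 3 and its neighbours. A step toward higher numbers, beyond the scatter, is expected from compound 3 to compound 4, that is a 12-fold higher number from compound 3 to compound 4 (1.08 log units; beyond the scatter), because compound 3 itself sits at 1.26 nM and the new group replaces the one carrying the basic nitrogen. Compound 4 is accordingly estimated at 15 nM, within a range from 2.5 nM to 100 nM.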

Compound 4, inhibition constant: 0.1 nM
For compound 4 the middle estimate is 150-fold (2.18 log units) above the measured one; measured number below the stated range.
By their numbers in this assay, from the lowest: compound 4; then compound 1; then compound 3; then compound 2.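

In this assay, going by these compounds alone, putting ((hydroxymethyl)carbonyl)amino in place of (carbamoylmethyl)(methyl)amino on a saturated chain carbon bound to a saturated ring carbon gives a 13-fold lower number from compound 3 to compound 4 (1.10 log units; beyond the scatter), the first change in one place that can be read. It shows that this position is sensitive to what it carries, since a single exchange there moves the number well beyond the scatter, with the rest of the structure unchanged. The entering group has 5 heavy atoms against 6 in the group that leaves, and 2 hydrogen-bond donors against 1, but no measurement at hand connects either difference to the size of the step.

The exchange alters several things at once, so the compounds shown do not separate the contribution of the hydroxyl from that of the carbonyl or of the lost methyl on nitrogen; acetylamino or (methoxyacetyl)amino at this place would bear directly on that question. On these data alone, it also remains open whether the same exchange gives a step of similar size when the fluorophenyl group on the sulfonyl is replaced by another aryl group.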